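A few compounds are considered here, and "the series" means these few. Any claim that something is new, unique, unknown or untested is made for them only; others in the source may bear on it.

Measured so far:
compound 1 `C[C@@H]1CN(c2nc(-c3cnn(C)c3)cnc2C#N)CCN1C(=O)C1CC1`: 39 mL/min/kg
compound 2 `CCC(=O)N1CCN(c2nc(-c3cnn(C)c3)ncc2C#N)C[C@H]1C`: < 36 mL/min/kg
compound 3 `Cn1cc(-c2ncc(C#N)c(N3C[C@@H]4C[C@H]3CN4CC3CC3)n2)cn1`: 158 mL/min/kg

Three compounds have been run in an ADME assay on microsomes from liver (Rattus norvegicus) for pharmacokinetics; on this read-out higher numbers stand for fast clearance and lower numbers for slow clearance. Compound 1 gives 39 mL/min/kg. Compound 2 sits at the limit of < 36 mL/min/kg in this assay, at which 1 of the 3 values shown sits, so its entry < 36 mL/min/kg is a limit rather than a number. Compound 3 gives 158 mL/min/kg, the higher of the two numbers, and its gap to compound 1 lies beyond the usual scatter. Compound 4 `Cn1cc(-c2ncc(C#N)c(N3C[C@@H]4C[C@H]3CN4c3cccc(F)c3)n2)cn1` has not yet been measured; it differs from compound 3 in one place: 3-fluorophenyl in place of cyclopropylmethyl on an amine nitrogen in a ring. Among the compounds with values here, no two measured compounds differ in a single place, so the data give no direct guide to the size of this change. A moderate fall in this assay is expected, a 1.4-fold lower number from compound 3 to compound 4 (0.16 log units; within the scatter). Compound 4 is estimated at 110 mL/min/kg, with a range from 45 mL/min/kg to 250 mL/min/kg.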

Compound 4, clearance: 1090 mL/min/kg
Compound 4: the middle estimate sits 9.9-fold (1.00 log units) below what was measured, outside the stated range (above it).
By their numbers in this assay, from the lowest: compound 1; then compound 3; then compound 4. At a limit, below all of these: compound 2.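

In this assay, putting 3-fluorophenyl in place of cyclopropylmethyl on this amine nitrogen in a ring gives a 6.9-fold higher number from compound 3 to compound 4 (0.84 log units; beyond the scatter). This single change is the only one in the set that isolates one position, and it shows that the group on this nitrogen can shift clearance well beyond the usual scatter. Nothing shown here accounts for the rise.

Going by these compounds, whether the rise follows the aromatic ring or its fluorine remains open. So does the effect on this nitrogen of a plain phenyl, a longer alkyl chain or a cyclopropanecarbonyl group.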